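From 1H-indol-6-yl to 4-(dimethylamino)phenyl on a shared core

A few compounds are considered here, and "the series" means these few. Any claim that something is new, unique, unknown or untested is made for them only; others in the source may bear on it.

Values in a functional assay on HCT-116 cells (Homo sapiens) for inhibition, read by CCK-8 assay, with a stated time of 48 h; a higher number here means a weaker inhibitor, a lower number a stronger inhibitor:
compound 1 `COc1cc(-c2ccnc3cc(-c4ccc(C)c(C)c4)nn23)cc(OC)c1OC` gives 261 nM
compound 2 `COc1cc(-c2ccnc3cc(-c4ccc5cc[nH]c5c4)nn23)cc(OC)c1OC` gives 187 nM
compound 3 `COc1cc(-c2ccnc3cc(-c4ccc(N(C)C)cc4)nn23)cc(OC)c1OC` has not yet been measured

Compound 2, at 187 nM, lies within the usual scatter of compound 1, at 261 nM, so neither compound stands apart from the other. The next change brings in 4-(dimethylamino)phenyl in place of 1H-indol-6-yl on an aromatic carbon of a five-membered aromatic ring with 2 nitrogen, and leads to compound 3: 4-(dimethylamino)phenyl in place of 1H-indol-6-yl on an aromatic carbon. Among the compounds with values here, only one measured step bears on this place, the exchange of 3,4-dimethylphenyl for 1H-indol-6-yl, and it stayed small: a 1.4-fold lower number from compound 1 to compound 2 (0.14 log units; within the scatter). One step is thin evidence and gives no direction for the new group, so no shift beyond the scatter is expected in this assay. The expected change is small: a 1.2-fold higher number from compound 2 to compound 3 (0.07 log units; within the scatter). For compound 3 the estimated value is 220 nM, with an expected range from 70 nM to 700 nM.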

Compound 3, half-maximal inhibitory concentration: 2050 nM
The estimate for compound 3 lay 9.3-fold (0.97 log units) below the measured number, and the stated range ends below it.
By their numbers in this assay, from the lowest: compounds 2 and 1 (each within the scatter of the next); then compound 3.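

In this assay this position, an aromatic carbon of a five-membered aromatic ring with 2 nitrogen, turns out not to be indifferent to the group it carries: replacing 1H-indol-6-yl with 4-(dimethylamino)phenyl gives an 11-fold higher number from compound 2 to compound 3 (1.04 log units; beyond the scatter) and so moves well beyond the scatter, which the earlier exchange at this place did not do. The same group also separates from 3,4-dimethylphenyl, with a 7.9-fold higher number from compound 1 to compound 3 (0.90 log units; beyond the scatter) on the shared core, so compound 3 stands apart from both earlier compounds rather than from a single partner. Nothing measured on these compounds accounts for this loss of inhibition, and the data offer no reason for it.

The compounds shown leave open whether the loss belongs to the dimethylamino group itself or to the whole 4-substituted phenyl arrangement, a question that plain phenyl, 4-aminophenyl or 4-methoxyphenyl at the same place would address. They also leave open how far the result extends to other amines, such as a morpholine or a piperidine on that phenyl ring.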